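Removing the carboxymethyl from compound 3: expected cytotoxicity

The compounds below may be only part of what the source reports. "The series", "measured", "known", "first", "only" and "open" are said of these compounds alone.

Compound 1 `COc1ccc2nc(Cl)c(/C=C3\SC(=S)NC3=O)cc2c1` and compound 2 `CCOc1ccc2nc(Cl)c(/C=C3\SC(=S)NC3=O)cc2c1` share their core with compound 3 `O=C(O)CN1C(=O)/C(=C/c2cc3cc(F)ccc3nc2Cl)SC1=S`. In a toxicity assay on THP-1 cells (Homo sapiens) for cytotoxicity, read by MTT assay, with a stated time of 48 h (on this read-out higher numbers stand for weaker inhibition of growth and lower numbers for stronger inhibition of growth), compound 1 gives only a limit, > 100 ug/mL. Compound 2 likewise gives only a limit, > 100 ug/mL. The step that the two limits leave unreadable from compound 1 to compound 2 is therefore not readable. Compound 3 also stands at a limit, > 100 ug/mL, and every value shown so far sits at the limit of > 100 ug/mL in this assay, at which 3 of the 3 values shown sit. Compound 4 `O=C1NC(=S)S/C1=C\c1cc2cc(F)ccc2nc1Cl` differs from compound 3 by hydrogen in place of carboxymethyl on an amide-type nitrogen in a ring. Among the compounds with values here, no measured step touches the amide-type nitrogen in the ring, and the one measured step has no size. With all values at the limit, no step beyond the scatter is expected, so the estimated step of a number no higher from compound 3 to compound 4 (the limit leaves the size open) is near zero. Compound 4 is expected to give about 100 ug/mL, between 50 ug/mL and 200 ug/mL, most probably reported again as a limit.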

Compound 4, concentration for 50% growth inhibition: > 100 ug/mL
Compound 4: no number, only a limit (the forecaster's own chance of this, stated with the estimate: 80%); the middle value sits exactly at the limit.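

No step from compound 1, compound 2 or compound 3 to compound 4 can be read, as all four values are limits rather than numbers: the limit of > 100 ug/mL in this assay, at which 4 of the 4 values shown sit.
The compounds shown leave open whether any of these changes alters growth inhibition at all.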